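Replacing a Vinyl with a Methoxy in an Inactive Series

The source may report more compounds than this note shows. Statements on the series, on what has been measured and on what is new or still open speak of the compounds shown alone.

Of the compounds shown here, three have been tested in an assay on isolated protein for inhibition of malate dehydrogenase, mitochondrial (Sus scrofa), with stated times of 45 min and 30 min; a lower number here means a stronger inhibitor, a higher number a weaker inhibitor. Compound 1 `Cc1ccc(S(=O)(=O)Nc2ccc(-c3nc4ccccc4o3)cc2)cc1` gives > 63000 nM, which is a limit of the assay rather than a number. Compound 2 `O=S(=O)(Nc1ccc(-c2nc3ccccc3o2)cc1)c1ccc(Cl)s1` gives > 63000 nM, again only a limit. The step that the two limits leave unreadable from compound 1 to compound 2 is therefore not readable. Compound 3 `C=Cc1ccc(S(=O)(=O)Nc2ccc3oc(-c4ccccc4)nc3c2)cc1` gives > 63000 nM, once more a limit and not a number. Compound 3 thus stands exactly where every measured compound stands, namely at the limit of > 63000 nM in this assay, at which 3 of the 3 values shown sit, and no number separates it from the others.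

Compound 4 `COc1ccc(S(=O)(=O)Nc2ccc3oc(-c4ccccc4)nc3c2)cc1` differs from compound 3 in a single place: methoxy in place of vinyl on an aromatic carbon. Within the data shown here, no measured step touches this part of the molecule. Among the measured compounds shown here, the only step between measured compounds, a step that the two limits leave unreadable from compound 1 to compound 2, changes the group on the sulfonyl sulfur instead, and its size cannot be read because both of its values are limits. With every value in this assay sitting at the same limit, there is no basis for expecting compound 4 to move away from it, and the step that the limit leaves unreadable from compound 3 to compound 4 is expected to be none beyond the scatter. Compound 4 is therefore expected near 80000 nM, with a range from 30000 nM to 300000 nM.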

Compound 4, half-maximal inhibitory concentration: > 63000 nM
Compound 4 gave a limit, no number (the forecaster's own chance of this, stated with the estimate: 85%); the middle value is on the limit's open side.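

Compound 3 gives > 63000 nM, a limit and not a number. Among these compounds, compound 4 gives > 63000 nM, also only a limit, so the change from vinyl to methoxy between compound 3 and compound 4 yields no step that can be read. Still open is whether any compound here has a readable strength, and which change would reveal one: the limit of > 63000 nM in this assay, at which 4 of the 4 values shown sit.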